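Urea replacement at the acyl position in the piperidine series

The source may hold more compounds than are shown below. What is called first, only, known or untested is meant among the compounds shown, and "the series" means these compounds.

Compound 3 `CC(C)[C@@H](NC(=O)CC1CC1)C(=O)N1CCC(c2ccc(Cl)cc2)CC1` stands second highest of the three numbers in an assay on THP-1 cells for displacement of a labelled ligand from C-C chemokine receptor type 1 (Homo sapiens); on this read-out lower numbers stand for stronger inhibition and higher numbers for weaker inhibition: compound 3 gives 46 nM, compound 2 `Cc1ccc(C(=O)N[C@@H](C(=O)N2CCC(c3ccc(Cl)cc3)CC2)C(C)C)cc1` gives 25 nM and compound 1 `Cc1ccc(CCC(=O)N[C@@H](C(=O)N2CCC(c3ccc(Cl)cc3)CC2)C(C)C)cc1` gives 105 nM. The step of a 1.8-fold higher number from compound 2 to compound 3 (0.26 log units; within the scatter) lies within the scatter, while a 2.3-fold lower number from compound 1 to compound 3 (0.36 log units; beyond the scatter) and a 4.2-fold lower number from compound 1 to compound 2 (0.62 log units; beyond the scatter) both pass beyond it, so the shorter acyl groups sit at the lower end here and the longest one at the higher end.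

Compound 4 `CC(C)[C@@H](NC(=O)Nc1ccccc1)C(=O)N1CCC(c2ccc(Cl)cc2)CC1` differs from compound 3 by anilino in place of cyclopropylmethyl on a carbonyl carbon. Within the data shown here, the nearest precedent is the aromatic group directly on the carbonyl carbon in compound 2, whose step to compound 3 was within the scatter; no measured step covers an anilino group or a phenylcarbamoyl in this position. The expected step of a 1.3-fold lower number from compound 3 to compound 4 (0.12 log units; within the scatter) is therefore small, probably towards a lower number but not clearly beyond the scatter. Compound 4 is estimated at 35 nM, within 12 nM to 100 nM.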

Compound 4, half-maximal inhibitory concentration: 616 nM
Compound 4: middle estimate off by 18-fold (1.25 log units), on the low side; the whole stated range lies below it.
By their numbers in this assay, from the lowest: compounds 2 and 3 (each within the scatter of the next); then compound 1; then compound 4.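

Among these compounds, the phenylcarbamoyl group is the first change at this carbonyl carbon to give a large step in this assay (a 13-fold higher number from compound 3 to compound 4 (1.13 log units; beyond the scatter)), and the step from the aromatic acyl group is also large (a 25-fold higher number from compound 2 to compound 4 (1.39 log units; beyond the scatter)). An aromatic ring at this place is therefore compatible with a low number in compound 2, but not with the anilino link in compound 4, which also stands above the longest acyl group (a 5.9-fold higher number from compound 1 to compound 4 (0.77 log units; beyond the scatter)). Nothing available here accounts for this loss.

The compounds shown leave open whether the anilino nitrogen itself matters, which a methylated anilino group or a cyclopropylamino group at the same carbonyl carbon would test. As far as these compounds go, it is also open whether a 4-methylanilino group would follow compound 4 or compound 2.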